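A few compounds are considered here, and "the series" means these few. Any claim that something is new, unique, unknown or untested is made for them only; others in the source may bear on it.

Measured so far in a functional assay on MCF7 cells (Homo sapiens) for cytotoxicity, read by MTT assay, with a stated time of 72 h; on this read-out lower numbers stand for stronger inhibition and higher numbers for weaker inhibition:
compound 1 `O=C1c2c[n+]([O-])c3ccccc3c2C(=O)c2c1c1ccccc1n2CCCCn1ccnc1` gives 130 nM
compound 2 `O=C1c2c[n+]([O-])c3ccccc3c2C(=O)c2c1c1ccccc1n2Cc1cn(C[C@H](O)CO)nn1` gives > 1000 nM
compound 3 `CC1(C)OC[C@@H](Cn2cc(Cn3c4c(c5ccccc53)C(=O)c3c[n+]([O-])c5ccccc5c3C4=O)nn2)O1` gives > 1000 nM

Compound 2 stands only at a limit of this assay and not at a number; its > 1000 nM is a limit. Compound 3 is likewise reported only as a limit, > 1000 nM. So (the limit of > 1000 nM in this assay, at which 2 of the 3 values shown sit), and only compound 1 carries a readable number.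

Among the measured compounds shown here, one measured step bears on the position in question: an at least 7.6-fold higher number from compound 1 to compound 2 (0.88 log units; beyond the scatter). The other step is not readable from two limits: a step that the two limits leave unreadable from compound 2 to compound 3.

Compound 4 `CN1CCN(CCCCCCn2c3c(c4ccccc42)C(=O)c2c[n+]([O-])c4ccccc4c2C3=O)CC1` changes compound 2 at the same place: 5-(4-methylpiperazin-1-yl)pentyl in place of 1-(2,3-dihydroxypropyl)-1H-1,2,3-triazol-4-yl on a saturated chain carbon bound to an aromatic nitrogen. The triazole and its diol leave entirely, and what enters is a flexible chain ending in a saturated ring with two nitrogens, closer in kind to the chain on compound 1, which gives 130 nM, than to the substituent of compound 2. The expectation is therefore that compound 4 recovers the number seen for compound 1, the step from compound 2 being expected as an at least 6.6-fold lower number from compound 2 to compound 4 (0.82 log units; beyond the scatter). Compound 4 is estimated at 150 nM, in the range 50 nM to 600 nM, with some chance that the assay again reports only a limit.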

Compound 4, half-maximal inhibitory concentration: 400 nM
The estimate for compound 4 lay 2.7-fold (0.43 log units) below the measured number, within the range that was stated.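

In this assay, the position on a saturated chain carbon bound to an aromatic nitrogen now carries a second readable number, so the loss seen with the 1-(2,3-dihydroxypropyl)-1H-1,2,3-triazol-4-yl group does not extend to every substituent placed there: replacing it with 5-(4-methylpiperazin-1-yl)pentyl gives an at least 2.5-fold lower number from compound 2 to compound 4 (0.39 log units; beyond the scatter). The value of compound 2, > 1000 nM, is a limit, so that step fixes only a minimum size. Among the compounds shown here, the methylpiperazine chain does not fully match the imidazole chain, with a 3.1-fold higher number from compound 1 to compound 4 (0.49 log units; beyond the scatter), so of the two readable groups at this position, the one on compound 1 gives the lower number.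

Compound 1 and compound 4 differ in both chain and terminal group, so the contribution of each remains unseparated; a 1H-imidazol-1-yl group on a longer chain, or a morpholine or dimethylamine on the chain of compound 4, would address this. The step between the two triazole compounds cannot be read, and how far either lies from the other readable numbers remains unknown: the limit of > 1000 nM in this assay, at which 2 of the 4 values shown sit.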